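Benzofuran in place of furan on two related cores

A few compounds are considered here, and "the series" means these few. Any claim that something is new, unique, unknown or untested is made for them only; others in the source may bear on it.

Compound 1 `O=c1[nH]cnc2c1c(-c1ccoc1)cn2[C@@H]1O[C@H](CO)[C@@H](O)[C@H]1O` carries a furan-3-yl group on a core whose activity was followed in a functional assay on K562 cells (Homo sapiens), read by MTT assay, with a stated time of 72 h; a higher number here means a weaker inhibitor, a lower number a stronger inhibitor. In this assay compound 1 gives 14500 nM. Compound 3 `O=c1[nH]cnc2c1c(-c1cc3ccccc3o1)cn2[C@@H]1O[C@H](CO)[C@@H](O)[C@H]1O` differs from it in one place: 1-benzofuran-2-yl in place of furan-3-yl on an aromatic carbon. In this assay compound 3 reaches only a limit of the measurement, > 20000 nM. The step of an at least 1.3-fold higher number from compound 1 to compound 3 (0.13 log units; that floor lies within the scatter) therefore sets only a floor on the loss, and the limit of > 20000 nM in this assay, at which 2 of the 3 values shown sit, marks where compound 3 sits.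

Compound 2 `Cc1nc(N)c2c(-c3ccoc3)cn([C@@H]3O[C@H](CO)[C@@H](O)[C@H]3O)c2n1` keeps the furan-3-yl group on a different core; the difference between the two cores is not broken down here. In this assay compound 2 gives a limit of the measurement, > 20000 nM.

Compound 4 `Cc1nc(N)c2c(-c3cc4ccccc4o3)cn([C@@H]3O[C@H](CO)[C@@H](O)[C@H]3O)c2n1` stands to compound 2 as compound 3 stands to compound 1: 1-benzofuran-2-yl in place of furan-3-yl on an aromatic carbon. This is the same change, made at the same place. On the core of compound 1 it carried the number from a measured value to the limit, and compound 2 already sits at that limit. Compound 4 is therefore expected to remain at or beyond the limit, the estimated step being a step that the limit leaves unreadable from compound 2 to compound 4. The estimate for compound 4 in this assay is 35000 nM, with a likely range from 15000 nM to 100000 nM, and most probably the assay will again report only a limit.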

Compound 4, half-maximal inhibitory concentration: 4990 nM
The estimate for compound 4 lay 7.0-fold (0.85 log units) above the measured number; the measured number lies below the stated range.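

In this assay, placing 1-benzofuran-2-yl in place of furan-3-yl on an aromatic carbon of the second core gives an at least 4.0-fold lower number from compound 2 to compound 4 (0.60 log units; beyond the scatter), so the change brings a gain on this core that exceeds the usual scatter. The same change does not carry over from one core to the other in this small series, since the steps on the two cores point in opposite directions and clearly differ: the same change on two cores in this assay, an at least 1.3-fold higher number (0.13 log units; that floor lies within the scatter) from compound 1 to compound 3 and an at least 4.0-fold lower number (0.60 log units; beyond the scatter) from compound 2 to compound 4, at least 5.5-fold (0.74 log units) apart, beyond the scatter of two such steps This pair of steps does not show which feature of the cores decides the outcome, and it gives only a floor for each step, not its full size, since some of the values are not numbers but a limit of the measurement: the limit of > 20000 nM in this assay, at which 2 of the 4 values shown sit.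

The compounds shown leave open whether the amine or the methyl group on the core of compound 2 accounts for the different outcome, as the two cores are compared only as wholes. For the compounds shown here, they also leave open whether a plain phenyl or a thiophene at the same place would follow compound 3 or compound 4, as furan-3-yl and 1-benzofuran-2-yl are the only groups seen there.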